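The source may hold more compounds than are shown below. What is called first, only, known or untested is meant among the compounds shown, and "the series" means these compounds.

For the measured compounds named here, compound 1 `Nc1nc(N)c2cc(CSC(=S)N3CCN(C4CCCCC4)CC3)ccc2n1` is the weakest of the three measured members: in a functional assay on MCF7 cells (Homo sapiens) for antiproliferative activity, read by MTT assay, with a stated time of 72 h (a lower number here means a stronger inhibitor, a higher number a weaker inhibitor), compound 1 gives 6800 nM, the highest number among them. Compound 2 `COc1ccc(N2CCN(C(=S)SCc3ccc4nc(N)nc(N)c4c3)CC2)cc1` gives 1580 nM in this assay, and compound 3 `Nc1nc(N)c2cc(CSC(=S)N3CCN(c4ccc([N+](=O)[O-])cc4)CC3)ccc2n1` gives 1470 nM.

The step to compound 4 `Nc1nc(N)c2cc(CSC(=S)N3CCN(c4ccccc4[N+](=O)[O-])CC3)ccc2n1` starts from compound 1 and makes one change: 2-nitrophenyl in place of cyclohexyl on an amine nitrogen in a ring.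

Going by the values given here, two measured steps bear on this change directly, since both also replace the cyclohexyl on the same ring nitrogen with an aromatic group. In this assay there was a 4.3-fold lower number from compound 1 to compound 2 (0.63 log units; beyond the scatter) and a 4.6-fold lower number from compound 1 to compound 3 (0.67 log units; beyond the scatter), both modest and both beyond the scatter, in the same direction. Between those two aromatic groups there was only a 1.1-fold lower number from compound 2 to compound 3 (0.03 log units; within the scatter), within the scatter, so the identity of the substituent on the aromatic ring made no clear difference in that pair. Among the compounds with values here, no measured compound carries the 2-nitrophenyl, so the effect of that particular group rests on no direct comparison.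

On this basis compound 4 is expected to follow the same pattern as compounds 2 and 3, with an estimated 4.0-fold lower number from compound 1 to compound 4 (0.60 log units; beyond the scatter). The estimated value for compound 4 in this assay is 1700 nM, with a likely range from 700 nM to 4500 nM.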

Compound 4, half-maximal inhibitory concentration: 4350 nM
Estimate against measurement, compound 4: 2.6-fold (0.41 log units) below; the measured number falls inside the stated range.
By their numbers in this assay, from the lowest: compounds 3 and 2 (each within the scatter of the next); then compounds 4 and 1 (each within the scatter of the next).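

In this assay, the 2-nitrophenyl does not repeat what the other two aromatic groups did on this ring nitrogen: there is a 1.6-fold lower number from compound 1 to compound 4 (0.19 log units; within the scatter), so in this pair an aromatic ring in place of cyclohexyl brings no clear difference. The aromatic groups also now separate, with a 3.0-fold higher number from compound 3 to compound 4 (0.47 log units; beyond the scatter) and a 2.8-fold higher number from compound 2 to compound 4 (0.44 log units; beyond the scatter), so moving the nitro from the 4-nitrophenyl to the 2-nitrophenyl arrangement counts for more here than exchanging methoxy for nitro did between compound 2 and compound 3, and compound 4 goes against the idea that any aromatic group on this nitrogen matches compounds 2 and 3. No measurement offered here accounts for the difference between the 2-nitrophenyl and the 4-nitrophenyl.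

The compounds shown leave open whether this result belongs to the nitro group itself or to any group at that place on the aromatic ring, a question that a 2-aminophenyl or a 2-methoxyphenyl would address. They also leave open where a plain phenyl, with no substituent at all, would stand against cyclohexyl on this ring nitrogen.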